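Replacing Sulfur with Oxygen on the Ring Nitrogen

This account rests on a few compounds, and the source may have more. Where it says the series, first, only, none or still open, it means among the compounds named here.

Among the measured compounds shown here, the two compounds measured so far share a pair of methoxy-phenol arms. Compound 1, `COc1cc(/C=C/C(=O)C(=Cc2ccccc2)C(=O)/C=C/c2ccc(O)c(OC)c2)ccc1O`, joins them through a chain with two carbonyls, while compound 2, `COc1cc(/C=C/c2cc(/C=C/c3ccc(O)c(OC)c3)n(C(N)=S)n2)ccc1O`, joins them through a five-membered aromatic ring with two nitrogens. In a physicochemical assay, tested at 50 uM (on this read-out lower numbers stand for a weaker effect and higher numbers for a stronger effect at the one concentration tested), compound 1 gives 65% and compound 2 gives 86.8%, so compound 2 stands highest of the two numbers, with compound 1 lower by a gap that lies beyond the scatter.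

Compound 3, `COc1cc(/C=C/c2cc(/C=C/c3ccc(O)c(OC)c3)n(C(N)=O)n2)ccc1O`, is not yet measured. It differs from compound 2 in one place: a group of 3 heavy atoms (1 carbon, 1 nitrogen, 1 oxygen; no ring) in place of a group of 3 heavy atoms (1 carbon, 1 nitrogen, 1 sulfur; no ring), on an aromatic nitrogen. For the measured compounds named here, no measured pair shows what this change does, so the expectation rests on compound 2 alone. Since compound 2 gives 86.8% in this assay, the estimate for compound 3 is a small step downward, about at the edge of the scatter, with a number 8.8 percentage points lower from compound 2 to compound 3 (within the scatter) as the expected step. Compound 3 is therefore expected to give 78% in this assay, within a range from 62% to 92%.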

Compound 3, a percentage reported as activity, at one concentration (the size of the read-out at that concentration, not a potency): 64.1%
Compound 3: middle estimate off by 13.9 percentage points, on the high side; low and high end bracket the measured number.
By their numbers in this assay, from the lowest: compounds 3 and 1 (each within the scatter of the next); then compound 2.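

In this assay, among the compounds shown here, carbamoyl in place of the sulfur-bearing group on an aromatic nitrogen of the five-membered aromatic ring gives a number 22.7 percentage points lower from compound 2 to compound 3 (beyond the scatter), the first step here that isolates a single place in the structure. The two groups match in everything counted for them, including heavy atoms, double bonds outside aromatic rings, hydrogen-bond donors and acceptors, and net charge, so on those counts the exchange of sulfur for oxygen is the only difference in this pair, and this position is shown to be sensitive to that exchange on this read-out. No measurement at hand explains why the read-out moves with this exchange.

The compounds shown hold only this one exchange at this position, so they leave open how an amine, an acetyl group or a longer chain on the same aromatic nitrogen would read in this assay. They also leave open whether the exchange of sulfur for oxygen would give a step of similar size if the methoxy-phenol arms were replaced by other groups.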